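Shifting the Ring Nitrogen in an Orexin Receptor Agonist

The source may hold more compounds than are shown below. What is called first, only, known or untested is meant among the compounds shown, and "the series" means these compounds.

Measured compounds:
compound 1 `COc1ccc(-c2cccc(C(=O)N(C)C)c2)cc1S(=O)(=O)Nc1cccc(NCCCNC(=O)c2cccc(C)c2)c1`: 103%
compound 2 `COc1ccc(-c2cccc(C(=O)N(C)C)c2)cc1S(=O)(=O)Nc1cccc(NCC(C)NC(=O)c2cccc(C)c2)c1`: 94%
compound 3 `COc1ccc(-c2cncc(C(=O)N(C)C)c2)cc1S(=O)(=O)Nc1cccc(NCCNC(=O)c2cccc(C)c2)c1`: 105%

In a functional assay on CHO-RD-HGA16 cells for agonist activity at Orexin/Hypocretin receptor type 1 (Homo sapiens), read by fluorescence and calcium flux, with a stated time of 30 min (on this read-out higher numbers stand for larger maximal responses and lower numbers for smaller maximal responses), compound 3 gives 105%, the highest of the three numbers; compound 1 sits within the scatter of it, while compound 2 lies beyond the scatter below it. Compound 4 `COc1ccc(-c2cccc(C(=O)N(C)C)n2)cc1S(=O)(=O)Nc1cccc(NCCNC(=O)c2cccc(C)c2)c1` has not been measured. It differs from compound 3 only in one place: 6-(dimethylcarbamoyl)pyridin-2-yl in place of 5-(dimethylcarbamoyl)pyridin-3-yl on an aromatic carbon. Within the data shown here, none of the measured steps touches this ring; the only step, a number 9 percentage points lower from compound 1 to compound 2 (within the scatter), concerns the chain and stays within the scatter. There is thus no measured basis for expecting a step beyond the scatter. Compound 4 is therefore expected to give a maximal response close to that of compound 3, with a number 5 percentage points lower from compound 3 to compound 4 (within the scatter) as the estimated step, namely 100% within a range of 85% to 112%.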

Compound 4, largest response reached (Emax), in percent of the reference or control that the assay uses: 100%
For compound 4 middle estimate and measured number coincide at the digits printed; the measured number falls inside the stated range.
By their numbers in this assay, from the lowest: compounds 2, 4, 1 and 3 (each within the scatter of the next, the first and the last beyond it).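

In this assay, among these compounds, 6-(dimethylcarbamoyl)pyridin-2-yl in place of 5-(dimethylcarbamoyl)pyridin-3-yl gives a number 5 percentage points lower from compound 3 to compound 4 (within the scatter), the first measured change on this ring. With the same atoms joined differently, the maximal response therefore does not separate these two placements of the ring nitrogen. Nothing at hand explains this result. The compounds shown leave open whether the maximal response would hold if a carboxylic acid or a primary amine took the place of the dimethylcarbamoyl group. They also leave open how a longer chain would fare alongside 6-(dimethylcarbamoyl)pyridin-2-yl.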